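The source may hold more compounds than are shown below. What is called first, only, known or untested is meant among the compounds shown, and "the series" means these compounds.

In a functional assay on MCF7 cells (Homo sapiens) for antiproliferative activity, read by CellTiter-Glo, with a stated time of 5 days (on this read-out higher numbers stand for weaker inhibition and lower numbers for stronger inhibition), compound 1 (`O=C(O)/C=C/c1ccc(/C(=C(\c2ccc(F)cc2Cl)C2CCC2)c2ccc3nccn3c2)cc1`) gives 4.4 nM and compound 2 (`O=C(O)/C=C/c1ccc(/C(=C(\c2ccc(C(F)(F)F)cc2Cl)C2CCC2)c2ccc3nccn3c2)cc1`) gives 5.1 nM and the two lie within the scatter of each other. Compound 3 (`O=C(O)/C=C/c1ccc(/C(=C(\c2ccc(F)cc2Cl)C2CCC2)c2ccc(-c3cn[nH]c3)cc2)cc1`) keeps the rest of compound 1 but carries 4-(1H-pyrazol-4-yl)phenyl on the double-bonded chain carbon (a group of 11 heavy atoms (9 carbon, 2 nitrogen; one five-membered aromatic ring with 2 hetero atoms, one six-membered aromatic ring of carbon only) in place of a group of 9 heavy atoms (7 carbon, 2 nitrogen; one five-membered aromatic ring with 2 hetero atoms, one six-membered aromatic ring with 1 hetero atom), on a double-bonded chain carbon bound to an aromatic carbon and a double-bonded chain carbon). Going by the values given here, the one measured step (a 1.2-fold higher number from compound 1 to compound 2 (0.06 log units; within the scatter)) sits at another place, so no measurement covers this change. With no direct guide, a moderate move to a higher number is expected in this assay (a 2.3-fold higher number from compound 1 to compound 3 (0.36 log units; beyond the scatter)), though the direction is uncertain. In this assay compound 3 is expected at 10 nM (estimated range 2.5 nM to 40 nM).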

Compound 3, half-maximal inhibitory concentration: 2.9 nM
Compound 3: middle estimate off by 3.4-fold (0.54 log units), on the high side; the measured number falls inside the stated range.
By their numbers in this assay, from the lowest: compounds 3, 1 and 2 (each within the scatter of the next).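

On the double-bonded chain carbon bound to an aromatic carbon and a double-bonded chain carbon, 4-(1H-pyrazol-4-yl)phenyl can replace the group of compound 1 while the numbers stay within the scatter in this assay, with a 1.5-fold lower number from compound 1 to compound 3 (0.18 log units; within the scatter). This position therefore tolerates a six-membered aromatic ring of carbon only and a hydrogen-bond donor, which the group in compound 1 lacks. No evidence is available that would explain this result. Still open, from the compounds shown here alone, is how a plain phenyl or a morpholine would read on this carbon, and whether the same swap holds alongside the trifluoromethyl of compound 2.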